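A halogen for a methoxy on the cinnamate ring

A few compounds are considered here, and "the series" means these few. Any claim that something is new, unique, unknown or untested is made for them only; others in the source may bear on it.

Compound 1 `COc1cc(OC)c(OC)cc1/C=C/COC(=O)/C=C/c1cccc(Br)c1`: 50%
Compound 2 `COc1cccc(/C=C/C(=O)OC/C=C/c2cc(OC)c(OC)cc2OC)c1`: 75%
Compound 3 `COc1ccc(/C=C/C(=O)OC/C=C/c2cc(OC)c(OC)cc2OC)cc1`: 100%

Three esters sharing one core were tested in a functional assay on the whole organism (strain Kunming) with Mus musculus as the target, with a stated time of 0.5 h, at a dose of 300 mg/kg by the intraperitoneal route; on this read-out lower numbers stand for a stronger effect and higher numbers for a weaker effect at the one dose given. Compound 3 stands highest of the three: the step of a number 25 percentage points higher from compound 2 to compound 3 (beyond the scatter) separates it from its nearest neighbour, and the step of a number 50 percentage points higher from compound 1 to compound 3 (beyond the scatter) from the furthest. As lower numbers mean a stronger effect, compound 3 is the weakest of the three in this assay.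

Compound 4 `COc1cc(OC)c(OC)cc1/C=C/COC(=O)/C=C/c1ccc(Cl)cc1` differs from compound 3 in one place: chloro in place of methoxy on an aromatic carbon. Among the compounds with values here, two measured steps bear on this. The step of a number 25 percentage points higher from compound 1 to compound 2 (beyond the scatter) shows that putting a methoxy where a bromo had been raised the number; the step of a number 50 percentage points higher from compound 1 to compound 3 (beyond the scatter), which also moved the group to the 4-position of the phenyl ring, raised it further. Compound 4 runs the other way, trading the methoxy of compound 3 for a halogen while keeping the 4-position, so a modest fall in this assay is expected, roughly the size of the methoxy-for-bromo step but uncertain in degree because the halogen and the position differ from those measured.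

For compound 4 in this assay an estimated step of a number 25 percentage points lower from compound 3 to compound 4 (beyond the scatter) is expected. Compound 4 is therefore estimated at 75%, with a range from 50% to 100%.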

Compound 4, a percentage reported as activity, at one dose (the size of the read-out at that dose, not a potency): 50%
Compound 4: middle estimate off by 25 percentage points, on the high side; the range from low to high includes it.
By their numbers in this assay, from the lowest: compounds 1 and 4 (each within the scatter of the next); then compound 2; then compound 3.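

In this assay the exchange of methoxy for chloro para to a large group gives a large step (a number 50 percentage points lower from compound 3 to compound 4 (beyond the scatter)), and here, unlike in the earlier comparison of compound 1 with compound 3, the group changes while its place stays the same. The remaining comparisons give a number 25 percentage points lower from compound 2 to compound 4 (beyond the scatter) and no change at the digits printed from compound 1 to compound 4 (within the scatter), so the 4-chlorophenyl and 3-bromophenyl esters cannot be told apart on this read-out, and both halogen-bearing esters now lie beyond the scatter from both methoxy esters, with none of these four compounds going against that pattern. No measurement shown here accounts for these differences.

Compound 1 and compound 4 differ in both the halogen and its place on the ring, so the shared result does not show whether either feature matters on its own. Going by these compounds, how an amine or a carboxylic acid para to a large group would compare with chloro and methoxy remains open, as does whether a bromo there would match the chloro of compound 4.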